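The source may report more compounds than this note shows. Statements on the series, on what has been measured and on what is new or still open speak of the compounds shown alone.

Of the compounds shown here, three built on one shared core have been tested in a functional assay on MCF7 cells (Homo sapiens) for cytotoxicity, read by MTT assay, with a stated time of 48 h; on this read-out higher numbers stand for weaker inhibition and lower numbers for stronger inhibition. Compound 1 `COc1ccc(N/C(CCNC2=CC(=O)c3ccccc3C2=O)=N\S(=O)(=O)c2ccc(C)cc2)cc1` gives 6030 nM in this assay. Compound 2 `Cc1ccc(S(=O)(=O)/N=C(/CCNC2=CC(=O)c3ccccc3C2=O)Nc2ccc(Cl)cc2)cc1` gives 7080 nM in this assay, and compound 3 `Cc1ccc(S(=O)(=O)/N=C(/CCNC2=CC(=O)c3ccccc3C2=O)Nc2cccc(C)c2)cc1` gives 8120 nM. Compound 3 holds the highest of the three numbers, yet the gaps to its neighbours are small: a 1.1-fold higher number from compound 2 to compound 3 (0.06 log units; within the scatter), and a 1.3-fold higher number from compound 1 to compound 3 (0.13 log units; within the scatter). The three values therefore cannot be told apart.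

Compound 4 `COc1ccc(N/C(CCNC2=CC(=O)c3ccccc3C2=O)=N\S(=O)(=O)c2ccc(C)cc2)cc1OC` is the next member, not yet measured. It differs from compound 3 in one place: 3,4-dimethoxyphenyl in place of 3-methylphenyl on an amine nitrogen. The closest guide is the step in which a 4-methoxyphenyl was exchanged for the 3-methylphenyl, a 1.3-fold higher number from compound 1 to compound 3 (0.13 log units; within the scatter), which stayed within the scatter; so did the exchange of a 4-chlorophenyl, a 1.1-fold higher number from compound 2 to compound 3 (0.06 log units; within the scatter). Across these three aryl groups on the amine nitrogen, the read-out in this assay has barely moved. For compound 4 no step beyond the scatter is expected, a 1.2-fold lower number from compound 3 to compound 4 (0.06 log units; within the scatter). Compound 4 is estimated at 7000 nM, with a likely range from 3000 nM to 16000 nM.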

Compound 4, half-maximal inhibitory concentration: 12300 nM
Compound 4: the middle estimate sits 1.8-fold (0.24 log units) below what was measured; the range from low to high includes it.
By their numbers in this assay, from the lowest: compounds 1, 2, 3 and 4 (each within the scatter of the next, the first and the last beyond it).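

Methoxy in place of hydrogen on an aromatic carbon gives a 2.0-fold higher number from compound 1 to compound 4 (0.31 log units; beyond the scatter) in this assay, the first step in this series to pass the scatter, though only a modest one. Placing 3,4-dimethoxyphenyl on the amine nitrogen instead of the other two aryl groups stays within the scatter, with a 1.5-fold higher number from compound 3 to compound 4 (0.18 log units; within the scatter) and a 1.7-fold higher number from compound 2 to compound 4 (0.24 log units; within the scatter). This position can therefore shift the read-out measurably, but the shift is small, and no measurement at hand accounts for it.

The compounds shown leave open whether a hydroxy or a dimethylamino group on this aromatic ring would move the number further. They also leave open how a pyridine ring or a benzyl group on the same amine nitrogen would compare with the aryl groups seen so far.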